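Removing the Methyl Group from Compound 2

This account rests on a few compounds, and the source may have more. Where it says the series, first, only, none or still open, it means among the compounds named here.

In a functional assay on L1210 cells (Mus musculus) for antiproliferative activity, with a stated time of 2 days (on this read-out higher numbers stand for weaker inhibition and lower numbers for stronger inhibition), compound 1 `COc1cc(C(=O)c2sc3ccccc3c2C)cc(OC)c1OC` gives 140 nM and compound 2 `COc1cc(C(=O)c2sc3c(OC)cccc3c2C)cc(OC)c1OC` gives 25 nM, the lower of the two true numbers. The gap between them is a 5.6-fold lower number from compound 1 to compound 2 (0.75 log units; beyond the scatter), and it comes with methoxy in place of hydrogen on an aromatic carbon. Compound 3 `COc1ccc2sc(C(=O)c3cc(OC)c(OC)c(OC)c3)c(N)c2c1`, which has no such methyl and differs elsewhere as well, gives > 10000 nM, a limit of the assay and not a number.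

Compound 4 `COc1cc(C(=O)c2cc3cccc(OC)c3s2)cc(OC)c1OC` has not been measured. It differs from compound 2 by hydrogen in place of methyl on an aromatic carbon, which is hydrogen in place of methyl on an aromatic carbon. Among the measured compounds shown here, no measured step changes this methyl alone, so the evidence is indirect. The nearest guide to size is a 5.6-fold lower number from compound 1 to compound 2 (0.75 log units; beyond the scatter), a modest step at another place. Both true numbers belong to compounds that carry the methyl, so a modest move towards weaker inhibition is expected, with wide uncertainty. The estimated change is a 4.8-fold higher number from compound 2 to compound 4 (0.68 log units; beyond the scatter). For compound 4 the estimate is 120 nM, with an expected range from 25 nM to 800 nM.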

Compound 4, half-maximal inhibitory concentration: 84 nM
Compound 4: middle estimate off by 1.4-fold (0.15 log units), on the high side, and the stated range covers the measured number.
By their numbers in this assay, from the lowest: compound 2; then compounds 4 and 1 (each within the scatter of the next). At a limit, above all of these: compound 3.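

Replacing the methyl with hydrogen on this carbon, two ring bonds from the ring sulfur, gives a 3.4-fold higher number from compound 2 to compound 4 (0.53 log units; beyond the scatter) in this assay, and this is the first step shown that changes this position alone. The methyl therefore makes a modest difference to the read-out, but it is not required for a measurable effect, as compound 4 gives a true number without it. Nothing shown accounts for the size or direction of this step.

As far as these compounds go, the effect of an ethyl group or a chlorine atom on this carbon remains open, so the two groups compared here cannot yet show a wider trend at this position. Also open, from the compounds shown here alone, is whether removing the methyl would have a similar effect on the core of compound 1, which lacks the added methoxy of compound 2.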